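Benzyloxy for bromo at the chalcone aryl end

The compounds below may be only part of what the source reports. "The series", "measured", "known", "first", "only" and "open" are said of these compounds alone.

Compound 1 `COCOc1cc(O)ccc1/C=C/C(=O)c1ccc(O)cc1O`: "not determined" (no result reported)
Compound 2 `COc1cc(OC)c(OC)cc1/C=C/C(=O)c1ccc(O)cc1O`: 31800 nM
Compound 3 `O=C(/C=C/c1ccc(Br)cc1)c1ccc(O)cc1O`: "not determined" (no result reported)

In a functional assay on MCF7 cells (Homo sapiens) for inhibition, read by sulforhodamine B assay, with a stated time of 48 h (on this read-out higher numbers stand for weaker inhibition of growth and lower numbers for stronger inhibition of growth), compound 2 gives 31800 nM, while compound 1 and compound 3 carry no number at all. Among the measured compounds shown here, compound 3 therefore stands nowhere on the scale; the only anchor is compound 2, which sits at weak inhibition. Compound 4 `O=C(/C=C/c1ccc(OCc2ccccc2)cc1)c1ccc(O)cc1O` differs from compound 3 by benzyloxy in place of bromo on an aromatic carbon. For the measured compounds named here, with no measured step between any pair, the size of this step in this assay cannot be read from the data; a change of about the scatter in either direction, or none, is the expectation. Compound 4 is estimated to give 20000 nM, with an expected range from 5000 nM to 80000 nM.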

Compound 4, concentration for 50% growth inhibition: 8000 nM
The estimate for compound 4 lay 2.5-fold (0.40 log units) above the measured number; low and high end bracket the measured number.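

No step can be read from compound 3 to compound 4, as compound 3 carries no single number. The compounds shown leave open how benzyloxy compares with bromo at this place. No further evidence bears on this result.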